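The source may report more compounds than this note shows. Statements on the series, on what has been measured and on what is new or still open speak of the compounds shown alone.

Working notes on a series of amides sharing one core, followed in a physicochemical assay for lipophilicity, read by HPLC; a higher number here means a more lipophilic compound, a lower number a more polar compound. Compound 2 (`Cc1ccsc1C(=CCCN(C)C(CCO)C(=O)NCc1ccc(F)cc1F)c1sccc1C`) gives 6.37. Compound 3 (`Cc1ccc(CNC(=O)C(CC(C)O)N(C)CCC=C(c2sccc2C)c2sccc2C)cc1`) gives 6.15, within the scatter of compound 2. Compound 1 (`Cc1ccsc1C(=CCCN(C)C(CCN)C(=O)NCc1ccc(Cl)cc1)c1sccc1C`) gives 5.85, lower than compound 2 by more than the scatter. Compound 2 therefore sits at the upper end of the measured set, level with compound 3.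

The next compound is compound 4 (`Cc1ccsc1C(=CCCN(C)C(CCO)C(=O)NC(C)c1ccccc1)c1sccc1C`), which differs from compound 2 as follows: 1-phenylethyl in place of 2,4-difluorobenzyl on an amide-type nitrogen. Both groups hold one six-membered aromatic ring of carbon only, with no hydrogen-bond donors or acceptors and no net charge. Among the measured compounds shown here, no measured pair differs in one place, so the series offers no direct precedent for this change. No step beyond the scatter is expected in this assay, and no direction is favoured. The estimated step is a number 0.07 log units lower from compound 2 to compound 4 (within the scatter), which stays within the scatter. Compound 4 is estimated at 6.3, with an expected range from 5.9 to 6.7.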

Compound 4, partition coefficient: 6.1
The estimate for compound 4 lay 0.20 log units above the measured number, within the range that was stated.
By their numbers in this assay, from the lowest: compounds 1, 4, 3 and 2 (each within the scatter of the next, the first and the last beyond it).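

In this assay, among the compounds shown here, 1-phenylethyl in place of 2,4-difluorobenzyl on the amide-type nitrogen gives a number 0.27 log units lower from compound 2 to compound 4 (within the scatter), the only comparison that differs in one place. For this one pair, the exchange of a substituent of 9 heavy atoms, including 2 fluorine, for one of 8 carbon atoms, each holding one six-membered aromatic ring of carbon only, does not produce a step beyond the scatter. Nothing available bears on the reason for this reading.

The shown compounds do not separate the loss of the two fluorine atoms from the change to 1-phenylethyl, which unsubstituted benzyl on the same nitrogen would address. From the compounds shown here alone, a longer chain such as 2-phenylethyl at this position, or a carboxylic acid on the ring, also remains open.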